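The source may report more compounds than this note shows. Statements on the series, on what has been measured and on what is new or still open speak of the compounds shown alone.

Compound 1 `CC(C)c1onc(-c2c(Cl)cccc2Cl)c1COc1ccc(-c2nc3ccc(C(=O)O)cc3n2C(C)C)cc1` gives 3.39 nM in an assay on Huh-7 cells for agonist activity at Bile acid receptor (Homo sapiens), read by a luciferase reporter; on this read-out higher numbers stand for an effect only at larger amounts of compound and lower numbers for an effect already at smaller amounts.
Compound 2 `CCC(CC)n1c(-c2ccc(OCc3c(-c4c(Cl)cccc4Cl)noc3C(C)C)cc2F)nc2ccc(C(=O)O)cc21` gives 1.3 nM in this assay.
Compound 3 `CC(C)c1onc(-c2c(Cl)cccc2Cl)c1COc1ccc(-c2nc3ccc(C(=O)O)cc3n2C)c(Cl)c1` gives 3.66 nM in this assay.

Among these three, compound 1 has the second highest number. Compound 3 sits closest to it, and the two lie within the usual scatter of this kind of measurement, so nothing can be said about which of them acts at the smaller amount. Compound 2 shows a lower number than compound 1, and that gap is beyond the scatter; compound 2 differs from compound 1 in more than one place, so no single cause can be read from the pair.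

Compound 4 `CC(C)Cn1c(-c2ccc(OCc3c(-c4c(Cl)cccc4Cl)noc3C(C)C)cc2)nc2ccc(C(=O)O)cc21` has not yet been measured. It differs from compound 1 as follows: isobutyl in place of isopropyl on an aromatic nitrogen. The carbon chain on the aromatic nitrogen grows by one carbon, with no change in ring count, donors, acceptors or charge. Among the compounds with values here, no measured pair in this set isolates this change, so the expectation rests on the small size of the difference alone. The step of a 1.1-fold lower number from compound 1 to compound 4 (0.05 log units; within the scatter) is expected to stay within the scatter, with no clear direction. Compound 4 is therefore expected to give about 3 nM, somewhere between 1 nM and 9 nM.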

Compound 4, half-maximal effective concentration: 5.26 nM
Compound 4: middle estimate off by 1.8-fold (0.24 log units), on the low side, within the range that was stated.
By their numbers in this assay, from the lowest: compound 2; then compounds 1, 3 and 4 (each within the scatter of the next).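

In this assay, within the data shown here, this is the first pair that isolates one change on the aromatic nitrogen: isobutyl in place of isopropyl gives a 1.6-fold higher number from compound 1 to compound 4 (0.19 log units; within the scatter), so the two compounds cannot be told apart on this read-out. At least for this pair, adding one carbon to the chain at this position leaves the number inside the usual scatter, with no direction that can be trusted. Nothing measured here offers any explanation for this result.

One small step says little about how much room for change this position has, since isopropyl and isobutyl are close relatives. A longer chain such as n-hexyl, a cyclopropyl ring or a chain ending in an amine on the same nitrogen could behave quite differently, and the compounds shown do not address this.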